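Series notes: the group on the thiocarbonyl carbon

This account rests on a few compounds, and the source may have more. Where it says the series, first, only, none or still open, it means among the compounds named here.

The shared core is the ketone of compound 1 `O=C1CC2(CCCCC2)Oc2c1ccc1ccccc21`, which in a functional assay on A549 cells (Homo sapiens) for antiproliferative activity, read by MTT assay, with a stated time of 96 h (on this read-out higher numbers stand for weaker inhibition and lower numbers for stronger inhibition), gives 10600 nM. Compound 2 `CSC(=S)N/N=C1\CC2(CCCCC2)Oc2c1ccc1ccccc21` carries a methylsulfanyl group on the thiocarbonyl carbon of the hydrazone and in this assay gives 3990 nM. Compound 3 `S=C(N/N=C1\CC2(CCCCC2)Oc2c1ccc1ccccc21)N1CCNCC1` carries piperazin-1-yl on that carbon and in this assay gives 12000 nM; this is the highest of the three numbers, with compound 1 nearest and within the scatter and compound 2 furthest, beyond it. Within the data shown here, the only measured step that alters the group on the thiocarbonyl carbon is a 3.0-fold higher number from compound 2 to compound 3 (0.48 log units; beyond the scatter), a modest shift beyond the scatter.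

Compound 4 `NCCCCCCC(=S)N/N=C1\CC2(CCCCC2)Oc2c1ccc1ccccc21` differs from compound 3 as follows: 6-aminohexyl in place of piperazin-1-yl on a thiocarbonyl carbon. The step from compound 2 to compound 3 is the one that bears on this change, since it too swaps the group on the thiocarbonyl carbon, and it was modest. Among the measured compounds shown here, a step of similar or smaller size is therefore plausible in this assay, but nothing in the data fixes its direction, and the change from a ring to an open chain has no measured counterpart here. The estimated step is a 1.5-fold lower number from compound 3 to compound 4 (0.18 log units; within the scatter). Compound 4 is expected to give about 8000 nM in this assay, with a range from 2500 nM to 25000 nM.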

Compound 4, half-maximal inhibitory concentration: 3240 nM
For compound 4 the middle estimate is 2.5-fold (0.39 log units) above the measured one, within the range that was stated.
By their numbers in this assay, from the lowest: compounds 4 and 2 (each within the scatter of the next); then compounds 1 and 3 (each within the scatter of the next).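

In this assay the group on the thiocarbonyl carbon now proves able to move the number in both directions: a 3.7-fold lower number from compound 3 to compound 4 (0.57 log units; beyond the scatter) reverses the earlier rise, while a 1.2-fold lower number from compound 2 to compound 4 (0.09 log units; within the scatter) stays within the scatter, so 6-aminohexyl and methylsulfanyl cannot be told apart here. Together with a 3.0-fold higher number from compound 2 to compound 3 (0.48 log units; beyond the scatter), this leaves piperazin-1-yl as the one group of the three that lies beyond the scatter from both others, and the amine-bearing open chain does not share its number even though both groups contain nitrogen. The two groups have equal counts of hydrogen-bond donors and acceptors, so those counts do not separate them, whereas the ring does differ, and nothing measured here explains the step.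

The compounds shown cannot separate the loss of the ring from the length of the chain, a question that a shorter amine such as 2-aminoethyl or a plain hexyl chain without its amine would address. Also open, as far as these compounds go, is whether other rings on this carbon, such as morpholin-4-yl or 4-methylpiperazin-1-yl, stay level with piperazin-1-yl.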